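Bromo for Phenyl on the Core of Compound 1

A few compounds are considered here, and "the series" means these few. Any claim that something is new, unique, unknown or untested is made for them only; others in the source may bear on it.

Measured compounds:
Compound 1 `Cn1c(-c2ccccc2)nc2c(Sc3ccccc3)ncnc21` — 1%
Compound 2 `Cn1c(-c2ccccc2)nc2c(Sc3ccc(F)cc3)ncnc21` — 9%
Compound 3 `Cn1c(-c2ccc([S+](C)[O-])cc2)nc2c(Sc3ccccc3)ncnc21` — 1%

In an assay on isolated protein for inhibition of Rho-associated protein kinase 1 (Homo sapiens), tested at 30 uM (a lower number here means less inhibition, a higher number more inhibition at the concentration tested (going by the name of the read-out)), compound 1 gives 1%. Compound 1 stands level with compound 3 at the digits reported, and the two share the lowest number of the three; compound 2 is the furthest from it, with a number 8 percentage points higher from compound 1 to compound 2 (within the scatter). The step of no change at the digits printed from compound 1 to compound 3 (within the scatter) is also within the scatter. All three compounds, then, sit at weak inhibition in this assay and do not differ beyond the scatter.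

Compound 4 `Cn1c(Br)nc2c(Sc3ccccc3)ncnc21` has not yet been measured. It differs from compound 1 by bromo in place of phenyl on an aromatic carbon. Neither measured step bears on this change: the step from compound 1 to compound 2 alters the phenyl sulfide ring, and the step from compound 1 to compound 3 adds a group to the phenyl that is now removed. With no guide from the data and all three measured values lying low, compound 4 is expected to show no step beyond the scatter, a number 2 percentage points higher from compound 1 to compound 4 (within the scatter). Compound 4 is therefore estimated at 3%, in the range 0% to 15%.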

Compound 4, a percentage reported as inhibition, at one concentration (the size of the read-out at that concentration, not a potency): 0%
Beside the measured number, compound 4's estimate is 3 percentage points above it; measured number inside the range.
By their numbers in this assay, from the lowest: compounds 4, 1, 3 and 2 (each within the scatter of the next).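

In this assay, bromo in place of phenyl on the aromatic carbon between two ring nitrogen atoms gives a number 1 percentage points lower from compound 1 to compound 4 (within the scatter), so this is the first of the compounds shown in which the whole phenyl leaves this place, where compound 3 only carried an added group on it. The number stays at the same low level without that ring, so no part of the inhibition seen at the concentration tested can be assigned to the phenyl. No measurement shown here accounts for this result.

What the compounds leave open is whether any group at this place can lift the number beyond the scatter, for example an amine, a carboxylic acid or a longer chain. With all four numbers low, they also do not show whether bromo and phenyl would differ in a compound with stronger inhibition.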